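From compound 1 to compound 4: adding an isobutyl group

The source may report more compounds than this note shows. Statements on the series, on what has been measured and on what is new or still open speak of the compounds shown alone.

In an ADME assay on HeLa cells (Homo sapiens) for cytotoxicity, read by MTT assay (on this read-out lower numbers stand for stronger inhibition and higher numbers for weaker inhibition), compound 1 `COC(=O)CNC(=O)CCC(=O)Oc1ccc(C[C@H]2C(=O)OC[C@@H]2Cc2ccc(OC)c(OC)c2)cc1OC` gives 179000 nM. Compound 2 `COc1ccc(C[C@H]2COC(=O)[C@@H]2Cc2ccc(OCC(=O)Nc3ccc(C)cc3)c(OC)c2)cc1OC` gives 228000 nM, and compound 3 `COc1ccc(C[C@H]2COC(=O)[C@@H]2Cc2ccc(OCC(=O)N3CCCCC3)c(OC)c2)cc1OC` gives 293000 nM. These three numbers cannot be told apart: a 1.3-fold higher number from compound 1 to compound 2 (0.11 log units; within the scatter), a 1.6-fold higher number from compound 1 to compound 3 (0.21 log units; within the scatter) and a 1.3-fold higher number from compound 2 to compound 3 (0.11 log units; within the scatter) all lie within the usual scatter, so compound 1 stands level with the other two.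

Compound 4 `COC(=O)[C@H](CC(C)C)NC(=O)CCC(=O)Oc1ccc(C[C@H]2C(=O)OC[C@@H]2Cc2ccc(OC)c(OC)c2)cc1OC` keeps the core of compound 1 and differs in one place: isobutyl in place of hydrogen on a saturated chain carbon bound to an amide-type nitrogen and a carbonyl carbon. Among the measured compounds shown here, no measured step makes this exact change. The closest evidence is the two steps away from compound 1 shown above, which replace a whole group on an oxygen on an aromatic ring and still stay within the scatter. A step beyond the scatter in this assay is therefore not expected here. The expected step is a 1.1-fold higher number from compound 1 to compound 4 (0.05 log units; within the scatter), which is no real change. For compound 4 the estimated value is 200000 nM, with an expected range from 100000 nM to 400000 nM.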

Compound 4, half-maximal inhibitory concentration: 53200 nM
The estimate for compound 4 lay 3.8-fold (0.58 log units) above the measured number, outside the stated range (below it).
By their numbers in this assay, from the lowest: compound 4; then compounds 1, 2 and 3 (each within the scatter of the next).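

Among the earlier compounds, replacing a whole group on an oxygen on an aromatic ring produced no step beyond the scatter. In this assay, the much smaller addition of isobutyl, with no ring, gives a 3.4-fold lower number from compound 1 to compound 4 (0.53 log units; beyond the scatter). This shows that a saturated chain carbon bound to an amide-type nitrogen and a carbonyl carbon is a place where the number can move, although the step is modest, and nothing shown explains why it occurs.

With isobutyl as the only group shown on this carbon, it remains open whether a methyl group or a longer chain would give a similar step. Going by these compounds, it is also open whether a benzyl group or an amine-bearing chain in the same place would keep the lower number.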